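The source may hold more compounds than are shown below. What is called first, only, known or untested is meant among the compounds shown, and "the series" means these compounds.

Compound 1 `NC(=O)CCn1nc(-c2ccccc2)ccc1=O`: -2.8%
Compound 2 `Cc1ccc(=S)n(CCC(=N)S)n1`: 48.5%
Compound 3 `CC1=NN(CC(C)C(=N)S)C(=O)CC1`: 15.6%

In a functional assay on the whole organism (stomach) for inhibition, with Rattus norvegicus as the target, at a dose of 100 mg/kg by the intraduodenal route (on this read-out lower numbers stand for less inhibition and higher numbers for more inhibition at the one dose given (going by the name of the read-out)), compound 1 gives -2.8%, the lowest of the three numbers. Compound 3 stands higher, beyond the scatter, and compound 2 stands higher still, also beyond the scatter; no single change links either of them to compound 1, so only their values can be compared. Compound 4 `N=C(S)CCn1nc(-c2ccccc2)ccc1=O` differs from compound 1 in one place: a group of 3 heavy atoms (1 carbon, 1 nitrogen, 1 sulfur; no ring) in place of a group of 3 heavy atoms (1 carbon, 1 nitrogen, 1 oxygen; no ring), on a saturated chain carbon, two bonds along the chain from an aromatic nitrogen. The two other measured compounds both show more inhibition than compound 1 on this assay, which hints that the change in compound 4 may move the number upward. The step is expected to be a number 27.8 percentage points higher from compound 1 to compound 4 (beyond the scatter), upward and beyond the scatter, though with much uncertainty. For compound 4 the expected value is 25%, ranging from 0% to 55%.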

Compound 4, a percentage reported as inhibition, in the whole organism at one dose (the size of the read-out at that dose, not a potency): 53.7%
For compound 4 the middle estimate is 28.7 percentage points below the measured one; the measured number falls inside the stated range.
By their numbers in this assay, from the lowest: compound 1; then compound 3; then compounds 2 and 4 (each within the scatter of the next).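

Among the compounds shown here, this is the first pair that isolates a single change. In this assay, replacing the carbamoyl with a group of equal heavy-atom count, with sulfur in place of oxygen, on the same saturated chain carbon gives a number 56.5 percentage points higher from compound 1 to compound 4 (beyond the scatter). This position therefore responds strongly to the change, even with the rest of compound 1 left intact. Nothing available explains why the number moves.

A carboxylic acid or an amine at this place remains untested among the compounds shown, as does a longer chain. Going by these compounds, it also remains open whether the same swap would have a similar effect on another core.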